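The source may hold more compounds than are shown below. What is called first, only, known or untested is meant among the compounds shown, and "the series" means these compounds.

Going by the values given here, in a functional assay on MCF7 cells (Homo sapiens) for antiproliferative activity (a lower number here means a stronger inhibitor, a higher number a weaker inhibitor), compound 2 `CC(C)=CCc1cc(C(=O)Nc2cc3ccc(OCCCN(C(C)C)C(C)C)c(C)c3oc2=O)ccc1O` gives 1310 nM, the only plain number among the two values shown. Compound 1 `CC(C)=CCc1cc(C(=O)Nc2cc3ccc(OCCCN4CCCCC4)c(C)c3oc2=O)ccc1O` reaches only a limit of the assay, > 50000 nM. Among the compounds with values here, the single measured step, an at least 38-fold lower number from compound 1 to compound 2 (1.58 log units; beyond the scatter), shows that exchanging the amine at the end of this chain can shift the result strongly. Compound 3 `CC(C)=CCc1cc(C(=O)Nc2cc3ccc(OCCCN(C)c4ccccc4)c(C)c3oc2=O)ccc1O` differs from compound 2 by methyl(phenyl)amino in place of diisopropylamino on a saturated chain carbon, three bonds along the chain from an oxygen on an aromatic ring. That measured step bears on this change only by showing the amine position is sensitive; its direction is not settled by it. The expected step is a 1.9-fold higher number from compound 2 to compound 3 (0.28 log units; within the scatter), a modest weakening. Compound 3 is therefore estimated at 2500 nM, between 600 nM and 15000 nM.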

Compound 3, half-maximal inhibitory concentration: > 50000 nM
Compound 3: no number, only a limit; the forecaster's own chance of this, stated with the estimate: 15%; middle value at least 20-fold (1.30 log units) from the limit.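

In this assay, methyl(phenyl)amino in place of diisopropylamino gives an at least 38-fold higher number from compound 2 to compound 3 (1.58 log units; beyond the scatter). Diisopropylamino is now the only one of three amines at this chain end that gives a plain number, so the earlier drop with piperidin-1-yl was not a single case. The step from compound 1 to compound 3 cannot be read, as both values are limits.

From the compounds shown here alone, whether dimethylamino, morpholin-4-yl or a longer chain would keep a plain number stays open. The order among the weaker amines also stays hidden: the limit of > 50000 nM in this assay, at which 2 of the 3 values shown sit.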